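Swapping a cyclopentyl for a trifluoromethyl-bearing benzyl group

A few compounds are considered here, and "the series" means these few. Any claim that something is new, unique, unknown or untested is made for them only; others in the source may bear on it.

Three close relatives sharing one core have been tested in an assay on isolated protein (kidney, strain Wistar) for displacement of a labelled ligand from Translocator protein (Rattus norvegicus), read by scintillation counting, with a stated time of 90 min; on this read-out lower numbers stand for stronger inhibition and higher numbers for weaker inhibition. Compound 1 `CCN(CC)C(=O)Cc1c(-c2ccc(OC3CCCC3)cc2)nn2c(C)cc(C)nc12` gives 1.5 nM. Compound 2 `CCN(CC)C(=O)Cc1c(-c2ccc(OCC3CCCC3)cc2)nn2c(C)cc(C)nc12` gives 2.1 nM, and compound 3 `CCN(CC)C(=O)Cc1c(-c2ccc(OCc3ccccc3C(F)(F)F)cc2)nn2c(C)cc(C)nc12` gives 1.4 nM. Among these three numbers compound 1 stands second highest, with compound 3 nearest and compound 2 furthest, and every gap between them lies within the scatter of this kind of measurement.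

Compound 4 `CCN(CC)C(=O)Cc1c(-c2ccc(OCc3ccc(C(F)(F)F)cc3)cc2)nn2c(C)cc(C)nc12` has not yet been measured. Compared with compound 1, the change is 4-(trifluoromethyl)benzyl in place of cyclopentyl on an oxygen on an aromatic ring. Within the data shown here, two measured steps bear on it. The closest comparison is the step to compound 3, where a benzyl group carrying a trifluoromethyl group already replaced the cyclopentyl: a 1.1-fold lower number from compound 1 to compound 3 (0.03 log units; within the scatter). The step to compound 2, a 1.4-fold higher number from compound 1 to compound 2 (0.15 log units; within the scatter), also stayed within the scatter. Both steps show that quite different groups on this oxygen gave numbers within the scatter of one another, so no step beyond the scatter is expected here either. The step from compound 1 to compound 4 in this assay is therefore expected to be a 1.1-fold higher number from compound 1 to compound 4 (0.05 log units; within the scatter). Compound 4 is estimated at 1.7 nM, with a likely range from 0.8 nM to 3.5 nM.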

Compound 4, inhibition constant: 1.6 nM
Estimate against measurement, compound 4: 1.1-fold (0.03 log units) above; the range from low to high includes it.
By their numbers in this assay, from the lowest: compounds 3, 1, 4 and 2 (each within the scatter of the next).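

In this assay, replacing cyclopentyl with 4-(trifluoromethyl)benzyl puts a group with more heavy atoms on this oxygen, yet the step is a 1.1-fold higher number from compound 1 to compound 4 (0.03 log units; within the scatter). The new information is that the trifluoromethyl group can sit at a second place on the benzyl ring without a step beyond the scatter, since exchanging 2-(trifluoromethyl)phenyl for 4-(trifluoromethyl)phenyl gives a 1.1-fold higher number from compound 3 to compound 4 (0.06 log units; within the scatter). The comparison with the cyclopentylmethyl compound agrees, at a 1.3-fold lower number from compound 2 to compound 4 (0.12 log units; within the scatter), so all four compounds now lie within the scatter of one another, and this position has so far tolerated both saturated rings and substituted aromatic rings.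

Nothing available here explains why such different groups read alike. From the compounds shown here alone, it remains open whether this tolerance extends to groups of another kind on this oxygen, such as an amine, a carboxylic acid or a long unbranched alkyl chain, or whether any of these would finally produce a step beyond the scatter.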